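Compound 3 to compound 4: a clearance question

The compounds below may be only part of what the source reports. "The series", "measured", "known", "first", "only" and "open" are said of these compounds alone.

Compound 1 `CCOc1nc(Cl)cc2nc(NCc3cc(C)c(-c4cn(C)nc4C)cn3)[nH]c12`: 1370 mL/min/kg
Compound 2 `Cc1cc(CNC(=O)Nc2cc(Cl)nc(OCC(F)F)c2)nnc1-c1cn(C)nc1C(F)(F)F`: < 167 mL/min/kg
Compound 3 `CCOc1cc(NC(=O)NCc2cc(C)c(-c3cn(C)nc3C(F)(F)F)nn2)cc(C#N)n1`: < 105 mL/min/kg

Among the compounds with values here, in an ADME assay on microsomes from liver (Mus musculus) for metabolic stability, read by LC-MS, with a stated time of 4 h, tested at 1 uM (on this read-out higher numbers stand for fast clearance and lower numbers for slow clearance), compound 1 gives 1370 mL/min/kg, the only true number among the three. Compound 2 is reported as < 167 mL/min/kg, which is a limit. Going by these compounds, compound 3 stands at < 105 mL/min/kg, also a limit and not a number, so its exact place on the scale is unknown.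

Compound 4 `CCOc1nc(Cl)cc(NC(=O)NCc2cc(C)c(-c3cn(C)nc3C(F)(F)F)nn2)c1C` carries 6-chloro-2-ethoxy-3-methylpyridin-4-yl in place of 2-cyano-6-ethoxypyridin-4-yl on an amide-type nitrogen. Within the data shown here, no measured pair in the set isolates this kind of change, so the expectation remains loose. A moderate upward step in this assay is expected, although it may not exceed the usual scatter. The estimated step is an at least 1.7-fold higher number from compound 3 to compound 4 (0.23 log units; that floor lies within the scatter), and it starts from a limit, so it is uncertain. For compound 4 the estimated clearance is 180 mL/min/kg, with an expected range of 60 mL/min/kg to 550 mL/min/kg.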

Compound 4, clearance: < 534 mL/min/kg
Compound 4: a limit, no number; the forecaster's own chance of this, stated with the estimate: 40%; the middle value lies beyond the limit too.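

In this assay compound 4 gives < 534 mL/min/kg, which is a limit. Within the data shown here, compound 3 is also only a limit, so no step between these two compounds can be read. Going by these compounds, it remains open how 6-chloro-2-ethoxy-3-methylpyridin-4-yl and 2-cyano-6-ethoxypyridin-4-yl actually compare in clearance.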